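The source may report more compounds than this note shows. Statements on the series, on what has been measured and on what is new or still open speak of the compounds shown alone.

Notes on the series. In an ADME assay on the whole organism with Oryza sativa as the target, tested at 10 uM (a lower number here means a stronger effect, a higher number a weaker effect of the compound at the concentration tested), compound 2 `CC(C)c1cccc(NC(=O)N[C@@H](C)c2ccccc2)c1` gives 86%, the second highest of the three numbers. Compound 3 `C[C@H](NC(=O)Nc1ccc(C(F)(F)F)cc1)c1ccccc1` gives 94%, which sits within the scatter of compound 2. Within the data shown here, compound 1 `CC(C)c1cccc(NC(=O)N[C@H](C)c2ccccc2)c1` gives 44%; the step of a number 42 percentage points higher from compound 1 to compound 2 (beyond the scatter) is the only measured step in this set, and it rests on (the fact that compounds 1 and 2 differ only in the configuration as drawn). Compound 4 `C[C@H](NC(=O)Nc1cccc(Cl)c1)c1ccccc1` differs from compound 2 by chloro in place of isopropyl on an aromatic carbon. Among the measured compounds shown here, no measured step changes the group on the aromatic ring, so none bears directly on this change; compound 3 shows only that another group on that ring gives a number within the scatter of compound 2. The step of a number 2 percentage points higher from compound 2 to compound 4 (within the scatter) is therefore expected to stay within the scatter. Compound 4 is estimated at 88%, ranging from 65% to 100%.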

Compound 4, a percentage reported as activity, at one concentration (the size of the read-out at that concentration, not a potency): 103%
For compound 4 the middle estimate is 15 percentage points below the measured one, outside the stated range (above it).
By their numbers in this assay, from the lowest: compound 1; then compounds 2, 3 and 4 (each within the scatter of the next, the first and the last beyond it).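

In this assay the group on this aromatic carbon, meta to a large group, now proves able to move the read-out by itself: chloro in place of isopropyl gives a number 17 percentage points higher from compound 2 to compound 4 (beyond the scatter) toward a weaker effect. Until now, only a change of configuration had produced a step beyond the scatter. Nothing at hand gives a reason for this step. Still open, from the compounds shown here alone, is whether an amine or a longer chain on that carbon would shift the number in either direction, and whether configuration matters as much with chloro present.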